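A Methyl Step Repeated in a Second Core

The source may report more compounds than this note shows. Statements on the series, on what has been measured and on what is new or still open speak of the compounds shown alone.

Compound 1 `CCC(C)C1NC(=O)N(C2CCCC2)C1=O`: > 200000 nM
Compound 2 `CC(C)C(NC(=O)NO)C(=O)NC1CCCC1`: > 200000 nM
Compound 3 `CC(C)C1NC(=O)N(C2CCCC2)C1=O`: > 200000 nM

In a functional assay on CCRF-CEM cells (Homo sapiens) for inhibition (on this read-out higher numbers stand for weaker inhibition and lower numbers for stronger inhibition), compound 3 gives only a limit of the assay. Compound 1 likewise gives only a limit in this assay. Compound 1 carries methyl in place of hydrogen on a saturated chain carbon, two bonds along the chain from a saturated ring carbon, and the step that the two limits leave unreadable from compound 3 to compound 1 cannot be read because the limit of > 200000 nM in this assay, at which 3 of the 3 values shown sit, holds both values. Compound 2 also gives only a limit in this assay. The difference between the core of compound 2 and the core of compound 3 is not broken down here. Compound 4 `CCC(C)C(NC(=O)NO)C(=O)NC1CCCC1` carries the same kind of change, (methyl in place of hydrogen on a saturated chain carbon, three bonds along the chain from an amide-type nitrogen and a carbonyl carbon); the place is not the same, being three bonds along the chain from an amide-type nitrogen and a carbonyl carbon rather than two bonds along the chain from a saturated ring carbon. The step of a number no higher from compound 2 to compound 4 (the limit leaves the size open) is expected to be unreadable in the same way because the limit of > 200000 nM in this assay, at which 3 of the 3 values shown sit, covers all three measured values. Compound 4 is therefore estimated at 200000 nM, most probably again reported only as a limit.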

Compound 4, half-maximal inhibitory concentration: > 100000 nM
Compound 4: a limit, no number; the forecaster's own chance of this, stated with the estimate: 85%; the middle value does not contradict the limit.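

In this assay compound 2 and compound 4 both give only limits of the assay, so the step between them cannot be read. The compounds shown leave open how large the methyl step is in either core, and in which direction it goes.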